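The source may hold more compounds than are shown below. What is called first, only, known or untested is meant among the compounds shown, and "the series" means these compounds.

Measured so far:
- compound 1 `Cc1ccc(S(=O)(=O)N2C=CNC(=O)[C@H]2CC(=O)N[C@H]2CCN(C)CC2(C)C)cc1` — < 14 mL.min-1.g-1
- compound 2 `CCN1CC[C@H](NC(=O)C[C@@H]2C(=O)NC=CN2S(=O)(=O)c2ccc(C)cc2)C(C)(C)C1` — < 50 mL.min-1.g-1
- compound 3 `Cc1ccc(S(=O)(=O)N2C=CNC(=O)[C@H]2CC(=O)N[C@H]2CCN(CC(C)C)CC2(C)C)cc1` — 27 mL.min-1.g-1

All three were run in an in vitro ADME assay on microsomes from liver (Homo sapiens) for pharmacokinetics; a higher number here means faster removal of the compound, a lower number slower removal. For compound 1 the value < 14 mL.min-1.g-1 is a limit of the assay and not a number (the limit of < 14 mL.min-1.g-1 in this assay, at which 1 of the 3 values shown sits). For compound 2 the value < 50 mL.min-1.g-1 is likewise a limit (the limit of < 50 mL.min-1.g-1 in this assay, at which 1 of the 3 values shown sits). Among the compounds with values here, compound 3 with 27 mL.min-1.g-1 gives the only number in the set. The change isopropyl in place of hydrogen on a saturated chain carbon bound to an amine nitrogen in a ring gives the step of an at least 1.9-fold higher number from compound 1 to compound 3 (0.28 log units; that floor lies within the scatter). The change methyl in place of hydrogen on a saturated chain carbon bound to an amine nitrogen in a ring gives the step that the two limits leave unreadable from compound 1 to compound 2, and the step that the limit leaves unreadable from compound 2 to compound 3 is unreadable as well.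

Compound 4 `Cc1ccc(S(=O)(=O)N2C=CNC(=O)[C@H]2CC(=O)N[C@H]2CCN(CC(C)(C)C)CC2(C)C)cc1` is not yet measured in this assay. It differs from compound 3 by methyl in place of hydrogen on a saturated chain carbon bound to three saturated chain carbons. Methyl in place of hydrogen is also the change made from compound 1 to compound 2, so the change occurs twice among these compounds. The two cores differ by the change isopropyl in place of hydrogen on a saturated chain carbon bound to an amine nitrogen in a ring already described. The place is not the same: from compound 1 to compound 2 the carbon is bound to an amine nitrogen in a ring, from compound 3 to compound 4 it is bound to three saturated chain carbons, so this is the same kind of change, not the same change.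

The earlier step that the two limits leave unreadable from compound 1 to compound 2 is unreadable, so it gives no size to carry over. The expected step of a 1.1-fold higher number from compound 3 to compound 4 (0.05 log units; within the scatter) therefore rests mainly on compound 3 and its value 27 mL.min-1.g-1, with the step held near unchanged. Compound 4 is estimated at 30 mL.min-1.g-1, expected between 12 mL.min-1.g-1 and 75 mL.min-1.g-1.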

Compound 4, intrinsic clearance in microsomes: 405 mL.min-1.g-1
Estimate against measurement, compound 4: 14-fold (1.13 log units) below; measured number outside the range, above it.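

In this assay, methyl in place of hydrogen on a saturated chain carbon bound to three saturated chain carbons, which reads as isobutyl to neopentyl, gives a 15-fold higher number from compound 3 to compound 4 (1.18 log units; beyond the scatter), while tert-butyl in place of methyl gives an at least 8.1-fold higher number from compound 2 to compound 4 (0.90 log units; beyond the scatter) and tert-butyl in place of hydrogen gives an at least 28-fold higher number from compound 1 to compound 4 (1.46 log units; beyond the scatter); the starting values of the last two steps are limits of the assay and not numbers. This shows that a single added methyl can produce a large step on this core, but it does not show that the size carries to another core or place: the only other methyl in place of hydrogen lies on a carbon bound to an amine nitrogen in a ring, and the steps between compound 1 and compound 2 and between compound 2 and compound 3 cannot be read. No measurement shown bears on why the step from isobutyl to neopentyl is so large.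

Open, as far as these compounds go, is whether this step belongs to the neopentyl group alone, or whether a straight butyl chain or a cyclopropylmethyl group on the same amine nitrogen would give a similar number. Also open, from the compounds shown here alone, is whether isobutyl to neopentyl gives a step of this size on any other core.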